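Brine shrimp cytotoxicity of aryl variants in the chalcone series

The source may report more compounds than this note shows. Statements on the series, on what has been measured and on what is new or still open speak of the compounds shown alone.

Compound 1 `Cc1ccc(S(=O)(=O)NC(=O)Nc2ccccc2C(=O)/C=C/c2ccc(N(C)C)cc2)cc1` was tested in an ADME assay on the whole organism for cytotoxicity, with Artemia salina as the target, with a stated time of 24 h (on this read-out higher numbers stand for an effect only at larger amounts of compound and lower numbers for an effect already at smaller amounts), where compound 1 gives 38.1 ug/mL, the highest of the three numbers, though each of the other two lies within the scatter of it. Compound 2 `CCc1cc(/C=C/C(=O)c2ccccc2NC(=O)NS(=O)(=O)c2ccc(C)cc2)cc(OC)c1OC` gives 19.2 ug/mL, and compound 3 `CCOc1cc(/C=C/C(=O)c2ccccc2NC(=O)NS(=O)(=O)c2ccc(C)cc2)ccc1O` gives 19.2 ug/mL. The steps of a 2.0-fold lower number from compound 1 to compound 2 (0.30 log units; within the scatter) and a 2.0-fold lower number from compound 1 to compound 3 (0.30 log units; within the scatter) are both small, as is no change at the digits printed from compound 2 to compound 3 (within the scatter). Compound 4 `COc1cc(/C=C/C(=O)c2ccccc2NC(=O)NS(=O)(=O)c2ccc(C)cc2)ccc1O` differs from compound 1 by 4-hydroxy-3-methoxyphenyl in place of 4-(dimethylamino)phenyl on a double-bonded chain carbon bound to a double-bonded chain carbon. Both measured replacements at this same place stayed within the scatter, so for compound 4 the expected step is a 1.5-fold lower number from compound 1 to compound 4 (0.18 log units; within the scatter), with no direction beyond the scatter. Compound 4 is therefore estimated at 25 ug/mL, within a range from 12 ug/mL to 50 ug/mL.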

Compound 4, concentration for half-maximal effect: 17.8 ug/mL
Compound 4: the middle estimate sits 1.4-fold (0.15 log units) above what was measured; measured number inside the range.
By their numbers in this assay, from the lowest: compounds 4, 2, 3 and 1 (each within the scatter of the next, the first and the last beyond it).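

In this assay, within the data shown here, 4-hydroxy-3-methoxyphenyl in place of 4-(dimethylamino)phenyl gives the first step at this place printed as beyond the scatter (a 2.1-fold lower number from compound 1 to compound 4 (0.33 log units; beyond the scatter)), though only a modest one. Hydrogen in place of methyl on the saturated chain carbon bound to an oxygen on an aromatic ring stays within the scatter (a 1.1-fold lower number from compound 3 to compound 4 (0.03 log units; within the scatter)), as does the exchange of the 3-ethyl-4,5-dimethoxyphenyl group (a 1.1-fold lower number from compound 2 to compound 4 (0.03 log units; within the scatter)). No available evidence bears on why the step from compound 1 is larger.

Still open, going by these compounds, is whether a carboxylic acid or a propoxy chain on this aryl group would give a step clearly larger than the scatter.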